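The source may report more compounds than this note shows. Statements on the series, on what has been measured and on what is new or still open speak of the compounds shown alone.

Measured so far:
Compound 1, `COc1ccccc1NC(=S)N1CCc2c(sc(NC(=O)c3ccccc3Cl)c2C(N)=O)C1`: 35200 nM
Compound 2, `CSc1ccccc1NC(=S)N1CCc2c(sc(NC(=O)c3ccccc3Cl)c2C(N)=O)C1`: 13800 nM
Compound 3, `COc1ccccc1C(=O)Nc1sc2c(c1C(N)=O)CCN(C(=S)Nc1ccccc1Cl)C2`: 20500 nM

Of the compounds shown here, three have been tested in a functional assay on MKN-74 cells (Homo sapiens) for antiproliferative activity, with a stated time of 24 h; a lower number here means a stronger inhibitor, a higher number a weaker inhibitor. Compound 1 and compound 2 share one core and differ in a single group: methylsulfanyl in place of methoxy on an aromatic carbon. In this assay that change gave a 2.6-fold lower number from compound 1 to compound 2 (0.41 log units; beyond the scatter). Compound 3 is built from the same atoms as compound 1, joined differently; the difference between the two cores is not broken down here. Compound 3 and compound 2 lie within the usual scatter of each other, and compound 3 and compound 1 do as well, so no order among compound 1, compound 2 and compound 3 is claimed, apart from the step between compound 1 and compound 2.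

Compound 4, `CSc1ccccc1C(=O)Nc1sc2c(c1C(N)=O)CCN(C(=S)Nc1ccccc1Cl)C2`, has not yet been measured. It stands to compound 3 as compound 2 stands to compound 1: methylsulfanyl in place of methoxy on an aromatic carbon. The place of the change reads the same in both pairs, though one bond further out the surroundings differ, (2-methoxyphenyl)amino in compound 1 against (2-methoxyphenyl)carbonyl in compound 3. Within the data shown here, with only one earlier example, the expected step from compound 3 to compound 4 in this assay is a 2.3-fold lower number from compound 3 to compound 4 (0.36 log units; beyond the scatter), set beside a 2.6-fold lower number from compound 1 to compound 2 (0.41 log units; beyond the scatter), and it rests on that single precedent. Compound 4 is therefore estimated at 9000 nM, with a likely range from 3500 nM to 25000 nM.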

Compound 4, half-maximal inhibitory concentration: 6550 nM
Compound 4: the middle estimate sits 1.4-fold (0.14 log units) above what was measured, within the range that was stated.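

In this assay, putting methylsulfanyl in place of methoxy on an aromatic carbon, ortho to a large group, gave a 3.1-fold lower number from compound 3 to compound 4 (0.50 log units; beyond the scatter), so the change that had lowered the number on the core of compound 1 did the same on a second core. The two steps match in direction and cannot be told apart in size: the same change on two cores in this assay, a 2.6-fold lower number (0.41 log units; beyond the scatter) from compound 1 to compound 2 and a 3.1-fold lower number (0.50 log units; beyond the scatter) from compound 3 to compound 4, 1.2-fold (0.09 log units) apart, within the scatter of two such steps Within this series the change therefore carried over between these two cores, but two pairs tested in a single cell assay do not establish a general rule for other cores, and they do not show what lies behind the lower numbers.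

The compounds shown leave open whether a longer chain such as ethylsulfanyl, or a quite different group such as an amine or a carboxylic acid, would give a lower or higher number in the same place on either core, and whether methylsulfanyl would act alike elsewhere on the six-membered aromatic ring. They also leave open whether the same step would appear in another cell line or at another exposure time, since all four values come from the one assay.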